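A few compounds are considered here, and "the series" means these few. Any claim that something is new, unique, unknown or untested is made for them only; others in the source may bear on it.

Measured so far:
Compound 1 `N=C(N)NCCC[C@H](NC(=O)CN(c1nc(Cl)nc2[nH]cnc12)C1CC1)C(=O)OCc1ccccc1` gives 10.2% in a functional assay on the whole organism (Tail, strain ICR) with Mus musculus as the target, in the tail flick test, with a stated time of 120 min, at a dose of 25 umol/kg by the oral route; on this read-out lower numbers stand for a weaker effect and higher numbers for a stronger effect at the one dose given.
Compound 2 `CC[C@H](C)[C@H](NC(=O)CN(c1ncnc2c1ncn2C1CCCCO1)C1CC1)C(=O)OCc1ccccc1` gives 20.4% in this assay.
Compound 3 `CC(C)[C@H](NC(=O)CN(c1nc(Cl)nc2[nH]cnc12)C1CC1)C(=O)OCc1ccccc1` gives 27.3% in this assay.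

Compound 2 stands second highest of these three numbers; its gap to compound 3 is within the scatter, its gap to compound 1 is beyond it. Compound 4 `O=C(CN(c1ncnc2c1ncn2C1CCCCO1)C1CC1)N[C@@H](CC(=O)OCc1ccccc1)C(=O)OCc1ccccc1` differs from compound 2 by (benzyloxycarbonyl)methyl in place of sec-butyl on a saturated chain carbon bound to an amide-type nitrogen and a carbonyl carbon. Among the measured compounds shown here, the only measured step at this place is a number 17.1 percentage points higher from compound 1 to compound 3 (beyond the scatter), where a smaller carbon-only group replaced a larger nitrogen-rich group and the number rose. Here a larger group with two hydrogen-bond acceptors replaces a small carbon-only one, so a modest fall is expected, as a number 8.4 percentage points lower from compound 2 to compound 4 (within the scatter). The estimate for compound 4 is 12%, expected between 3% and 24%.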

Compound 4, a percentage reported as activity, at one dose (the size of the read-out at that dose, not a potency): 7.82%
Estimate against measurement, compound 4: 4.2 percentage points above; the measured number falls inside the stated range.
By their numbers in this assay, from the lowest: compounds 4 and 1 (each within the scatter of the next); then compounds 2 and 3 (each within the scatter of the next).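

The change to (benzyloxycarbonyl)methyl gives a number 12.6 percentage points lower from compound 2 to compound 4 (beyond the scatter) in this assay, so this place on the chain also responds on the core of compound 2, not only on the core of compound 1. In both pairs that differ here, the larger group carries the lower number, as a number 17.1 percentage points higher from compound 1 to compound 3 (beyond the scatter) also shows. Nothing here tells which feature of the entering group goes with the fall.

As far as these compounds go, it remains open whether a free carboxylic acid, an amine or a plain longer carbon chain at this place would hold the number of compound 2.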